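The source may report more compounds than this note shows. Statements on the series, on what has been measured and on what is new or still open speak of the compounds shown alone.

In an ADME assay on NCM460 cells (Homo sapiens) for cytotoxicity, read by CCK-8 assay, with a stated time of 48 h (a higher number here means a weaker inhibitor, a lower number a stronger inhibitor), the three measured compounds all sit at the top of the range. Compound 1, `COc1ccc(/C=C\c2cc(OC)c(OC)c(OC)c2)cc1OCc1ccc(CN2CC(C(=O)O)C2)cc1`, gives only a limit, > 50000 nM. Compound 3, `COc1ccc(/C=C\c2cc(OC)c(OC)c(OC)c2)cc1OCc1ccc(CN2CCCC[C@@H]2C(=O)O)cc1`, likewise gives only a limit, > 50000 nM. Compound 2, `COc1ccc(/C=C\c2cc(OC)c(OC)c(OC)c2)cc1OCc1ccc(CN2CC[C@H](O)C2)cc1`, gives a number, 51000 nM, which sits right where the other two are capped, so compound 3 stands alongside the others with no distinction visible among them. The steps a step that the limit leaves unreadable from compound 1 to compound 2, a step that the two limits leave unreadable from compound 1 to compound 3 and a step that the limit leaves unreadable from compound 2 to compound 3 are all left unreadable by the limit of > 50000 nM in this assay, at which 2 of the 3 values shown sit, so none of them shows any shift in this assay.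

Compound 4, `COc1ccc(/C=C\c2cc(OC)c(OC)c(OC)c2)cc1OCc1ccc(CNC(C)(C)C(=O)O)cc1`, carries the change ((1-carboxy-1-methylethyl)amino in place of 2-carboxypiperidin-1-yl on a saturated chain carbon bound to an aromatic carbon). Because the measured steps a step that the two limits leave unreadable from compound 1 to compound 3 and a step that the limit leaves unreadable from compound 2 to compound 3 are unreadable and every value shown sits at or beside (the limit of > 50000 nM in this assay, at which 2 of the 3 values shown sit), no step in either direction is expected beyond the scatter. Compound 4 is therefore expected to stay at the limit as well, with a number no higher from compound 3 to compound 4 (the limit leaves the size open) expected to be nil. The estimate for compound 4 in this assay is 50000 nM, expected to fall between 25000 nM and 100000 nM, most likely reported only as a limit.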

Compound 4, half-maximal inhibitory concentration: > 50000 nM
Compound 4: only a limit was reported (the forecaster's own chance of this, stated with the estimate: 70%); the middle value sits exactly at the limit.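

Compound 4 gives only a limit, so the steps to it from compound 1, compound 2 and compound 3 cannot be read in this assay: the limit of > 50000 nM in this assay, at which 3 of the 4 values shown sit.

The compounds shown leave open whether any group on this saturated chain carbon bound to an aromatic carbon would give a lower number in this assay.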